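Removing the nitro group from compound 2: series notes

This account rests on a few compounds, and the source may have more. Where it says the series, first, only, none or still open, it means among the compounds named here.

Compound 1, `CC(C)c1ccc(-c2nc(SCc3cn(CC(=O)NC(=O)Nc4ccccn4)nn3)nc(Nc3cccc(C(F)(F)F)c3)c2C#N)cc1`, gives > 64000 nM in a functional assay on MGC-803 cells (Homo sapiens) for inhibition, read by MTT assay, with a stated time of 72 h (a higher number here means a weaker inhibitor, a lower number a stronger inhibitor), a limit of the assay rather than a number.
Compound 2, `CC(C)c1ccc(-c2nc(SCc3cn(CC(=O)NC(=O)Nc4ccccn4)nn3)nc(Nc3cccc([N+](=O)[O-])c3)c2C#N)cc1`, gives > 64000 nM in this assay, again a limit.

Both values shown sit at the limit of > 64000 nM in this assay, at which 2 of the 2 values shown sit, so compound 2 cannot be placed relative to compound 1. The step that the two limits leave unreadable from compound 1 to compound 2 is unreadable. Compound 2 therefore stands only at a limit, with no readable step around it.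

Compound 3, `CC(C)c1ccc(-c2nc(SCc3cn(CC(=O)NC(=O)Nc4ccccn4)nn3)nc(Nc3ccccc3)c2C#N)cc1`, differs from compound 2 by hydrogen in place of nitro on an aromatic carbon. Within the data shown here, no measured step bears on this change; the only step recorded is unreadable. The expectation for compound 3 is thus anchored to the limit at which compound 2 sits, with wide uncertainty. Compound 3 is estimated at 80000 nM (range 20000 nM to 300000 nM) in this assay, most probably again reported as a limit. The step that the limit leaves unreadable from compound 2 to compound 3 is expected to be none beyond the scatter.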

Compound 3, half-maximal inhibitory concentration: 15800 nM
The estimate for compound 3 lay 5.1-fold (0.70 log units) above the measured number; measured number outside the range, below it.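

Hydrogen on this aromatic carbon gives, in this assay, an at least 4.0-fold lower number from compound 2 to compound 3 (0.60 log units; beyond the scatter) and an at least 4.0-fold lower number from compound 1 to compound 3 (0.60 log units; beyond the scatter). Nitro and trifluoromethyl at this place therefore both go with a weaker result than hydrogen, a comparison that compound 1 and compound 2 alone could not offer. Each step is only a lower bound, and the step between the two substituted compounds cannot be read: the limit of > 64000 nM in this assay, at which 2 of the 3 values shown sit.

On these data alone, whether a fluorine, a methyl, a methoxy or an amine on this aromatic carbon would keep the number of compound 3, or improve on it, stays open. Also open, as far as these compounds go, is whether the same change at other places on this anilino ring would give a step of similar size.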